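The compounds below may be only part of what the source reports. "The series", "measured", "known", "first", "only" and "open" are said of these compounds alone.

Of the compounds shown here, three from this series have been measured in an assay on HEK-293T cells for inhibition of diacylglycerol lipase-alpha (Homo sapiens), read by colorimetric assay; a lower number here means a stronger inhibitor, a higher number a weaker inhibitor. Compound 1 `O=C(CCCCCc1ccccc1)c1nc2ncccc2[nH]1` gives 1230 nM and compound 2 `O=C(CCCCCc1ccccc1)c1nc2ccc(Br)cc2o1` gives 5890 nM. Compound 3 `O=C(CCCCCCc1ccccc1)c1nc(C(=O)C(F)(F)F)co1` gives 123 nM, the lowest of the three numbers; its nearest neighbour is compound 1, whose number stands higher by a gap beyond the usual scatter, and the furthest is compound 2, whose number stands higher still, also beyond the scatter. No two of these compounds differ in only one place, so no single-point step has been recorded among them.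

Compound 4 `O=Cc1coc(C(=O)CCCCCCc2ccccc2)n1` has not yet been measured. It differs from compound 3 by hydrogen in place of trifluoromethyl on a carbonyl carbon: the trifluoromethyl leaves and a hydrogen enters on the carbonyl carbon whose other neighbour is an aromatic carbon, so that, cut one bond further out, the change reads (trifluoromethyl)carbonyl to formyl.

For the measured compounds named here, since no measured pair shows this kind of change, the expectation rests on compound 3 at 123 nM as the starting point. Compound 4 is expected to give a higher number, a step of moderate size in the direction of weaker inhibition. This estimate means a step of a 4.9-fold higher number from compound 3 to compound 4 (0.69 log units; beyond the scatter), expected to lie beyond the scatter. Compound 4 is therefore estimated at 600 nM, with a range from 150 nM to 3000 nM.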

Compound 4, half-maximal inhibitory concentration: 1510 nM
Compound 4: middle estimate off by 2.5-fold (0.40 log units), on the low side; measured number inside the range.
By their numbers in this assay, from the lowest: compound 3; then compounds 1 and 4 (each within the scatter of the next); then compound 2.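

In this assay, hydrogen in place of trifluoromethyl on a carbonyl carbon whose other neighbour is an aromatic carbon brings a 12-fold higher number from compound 3 to compound 4 (1.09 log units; beyond the scatter), a large step in the direction of weaker inhibition. For the compounds shown here, this is the first comparison in which only one place changes, and it shows that the number responds strongly to what sits on this carbonyl carbon, whereas the earlier compounds differed in more than one place and could not isolate any single change. The step does not remove inhibition, since compound 4 still gives 1510 nM, but nothing available here bears on why the change has this size.

With only two groups compared at this place, the compounds shown leave open where a methyl, a nitrile or a carboxylic acid in place of the (trifluoromethyl)carbonyl would fall relative to these two. They also leave open whether the same change would give a step of similar size on a longer chain or on the core of compound 1.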